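The source may hold more compounds than are shown below. What is called first, only, known or untested is meant among the compounds shown, and "the series" means these compounds.

In an ADME assay on Vero cells (Chlorocebus sabaeus) for cytotoxicity, with a stated time of 7 days (a lower number here means that less compound is tolerated, a higher number that more compound is tolerated), compound 2 `COc1ccc2[nH]c(C(=O)N3CC(=O)N(Cc4ccccc4)[C@@H](COCc4ccccc4)C3)cc2c1` gives > 30000 nM, which is a limit. Compound 1 `COc1cccc(CN2C(=O)CN(C(=O)c3cc4cc(OC)ccc4[nH]3)C[C@@H]2COCc2ccccc2)c1` gives > 10000 nM, also a limit. Compound 3 `COc1cccc(CN2C(=O)CN(C(=O)c3cc4cc(OC)ccc4[nH]3)C[C@@H]2CC2CCCCC2)c1` gives > 10000 nM, again a limit. Compound 4 `COc1ccc2[nH]c(C(=O)N3CC(=O)N(Cc4ccccc4)[C@@H](N4[C@H](C)CCC[C@@H]4C)C3)cc2c1` differs from compound 2 by 2,6-dimethylpiperidin-1-yl in place of (benzyloxy)methyl on a saturated ring carbon. Two measured changes bear on this: a step that the two limits leave unreadable from compound 1 to compound 3, which also removes a benzyloxy group, and a step that the two limits leave unreadable from compound 1 to compound 2. Neither has a readable size, so the expectation rests only on all three compounds ending in limits. The expected step, an at least 1.2-fold lower number from compound 2 to compound 4 (0.07 log units; that floor lies within the scatter), is none beyond the scatter, with no direction expected. Compound 4 is estimated at 25000 nM, with an expected range from 8000 nM to 60000 nM.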

Compound 4, half-maximal cytotoxic concentration: 1400 nM
Compound 4: the middle estimate sits 18-fold (1.25 log units) above what was measured; the whole stated range lies above it.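

In this assay, 2,6-dimethylpiperidin-1-yl in place of (benzyloxy)methyl on a saturated ring carbon gives an at least 21-fold lower number from compound 2 to compound 4 (1.33 log units; beyond the scatter), so a change at this position can bring the read-out well down. Compound 4 is the first compound shown with a value that is a number and not a limit. The earlier steps cannot be read, as those compounds end in limits: the limit of > 10000 nM in this assay, at which 2 of the 4 values shown sit.

From the compounds shown here alone, what remains open is whether the lower number comes from the piperidine ring itself or from its two methyl groups. A plain piperidin-1-yl or a morpholin-4-yl on this carbon would separate the two, and neither is among the compounds shown.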